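Aryl oxygen substituent walk: compound 3 to compound 4

This account rests on a few compounds, and the source may have more. Where it says the series, first, only, none or still open, it means among the compounds named here.

Measured in an assay for binding affinity to histone acetyltransferase KAT2B (Homo sapiens), read by HTRF, with a stated time of 15 h; a higher number here means a weaker inhibitor, a lower number a stronger inhibitor:
Compound 1, `CN1C[C@H](Nc2nc3cc[nH]c3c(=O)n2C)C[C@H](c2ccccc2)C1`: 41 nM
Compound 2, `CN1C[C@H](Nc2nc3cc[nH]c3c(=O)n2C)C[C@H](c2ccc(OC(F)(F)F)cc2)C1`: 17 nM
Compound 3, `CN1C[C@H](Nc2nc3cc[nH]c3c(=O)n2C)C[C@H](c2ccc(O)cc2)C1`: 30 nM

Compound 3 stands second highest of the three numbers; its gaps to compound 1 and to compound 2 both lie within the scatter. Compound 4, `COc1ccc([C@H]2C[C@@H](Nc3nc4cc[nH]c4c(=O)n3C)CN(C)C2)cc1`, differs from compound 3 by methyl in place of hydrogen on an oxygen on an aromatic ring. Among the measured compounds shown here, the steps that bear on this oxygen are a 1.8-fold higher number from compound 2 to compound 3 (0.25 log units; within the scatter) (within the scatter) and, on the same ring carbon, a 2.4-fold lower number from compound 1 to compound 2 (0.38 log units; beyond the scatter) (modest) and a 1.4-fold lower number from compound 1 to compound 3 (0.14 log units; within the scatter) (within the scatter). A methyl on that oxygen sits between hydroxy and trifluoromethoxy, so the expected step is small: a 1.2-fold lower number from compound 3 to compound 4 (0.08 log units; within the scatter), not beyond the scatter. Compound 4 is therefore estimated at 25 nM, with a range of 12 nM to 55 nM.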

Compound 4, half-maximal inhibitory concentration: 32 nM
The estimate for compound 4 lay 1.3-fold (0.11 log units) below the measured number, within the range that was stated.
By their numbers in this assay, from the lowest: compounds 2, 3, 4 and 1 (each within the scatter of the next, the first and the last beyond it).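

In this assay, methyl on the oxygen of the 4-hydroxyphenyl group leaves the number unchanged within the scatter (see a 1.1-fold higher number from compound 3 to compound 4 (0.03 log units; within the scatter)), so this position does not depend on keeping the hydrogen on that oxygen. Methoxy also cannot be separated from trifluoromethoxy (see a 1.9-fold higher number from compound 2 to compound 4 (0.27 log units; within the scatter)) or from hydrogen on the aromatic carbon (see a 1.3-fold lower number from compound 1 to compound 4 (0.11 log units; within the scatter)), leaving the step (see a 2.4-fold lower number from compound 1 to compound 2 (0.38 log units; beyond the scatter)) as the only one in this set beyond the scatter. No measurement available here explains this flat response.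

From the compounds shown here alone, whether an amine, a carboxylic acid or a longer alkoxy chain on this aromatic carbon would move the number beyond the scatter remains open.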